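The source may report more compounds than this note shows. Statements on the series, on what has been measured and on what is new or still open speak of the compounds shown alone.

Compound 1 `COC(CCn1cnc2c(NCc3ccc(C(=O)Nc4ccccc4N)cc3)nc(Cl)nc21)OC` gives 6.39% in a functional assay on HCT-116 cells (Homo sapiens) for antiproliferative activity, read by CCK-8 assay, with a stated time of 72 h, tested at 2 uM; a higher number here means a stronger effect of the compound at the concentration tested, a lower number a weaker effect. Among the compounds with values here, the only other number so far, from compound 2 `CC(C)n1cnc2c(Nc3ccccc3)nc(NCOCc3ccc(C(=O)Nc4ccccc4N)cc3)nc21`, is 6.85%, within the scatter of compound 1, so neither stands apart and both are small numbers in this assay. Compound 3 `CCC(C)n1cnc2c(NCc3ccc(C(=O)Nc4ccccc4N)cc3)nc(Cl)nc21` differs from compound 1 by sec-butyl in place of 3,3-dimethoxypropyl on an aromatic nitrogen. Within the data shown here, no step between measured compounds is available to size this change, and the two measured values leave little room for a drop. A small step, not beyond the scatter, is expected in this assay, a number 2.6 percentage points higher from compound 1 to compound 3 (within the scatter). Compound 3 is therefore estimated at 9%, between -4% and 24%.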

Compound 3, a percentage reported as inhibition, at one concentration (the size of the read-out at that concentration, not a potency): 74.6%
Compound 3: the middle estimate sits 65.6 percentage points below what was measured, and the stated range ends below it.
By their numbers in this assay, from the lowest: compounds 1 and 2 (each within the scatter of the next); then compound 3.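

The nitrogen substituent on the five-membered ring is a sensitive position in this assay: sec-butyl in place of 3,3-dimethoxypropyl gives a number 68.2 percentage points higher from compound 1 to compound 3 (beyond the scatter), with the rest of the structure unchanged. The swap replaces a chain of 7 heavy atoms and 2 hydrogen-bond acceptors with one of 4 heavy atoms and no acceptors, so chain size and acceptor count change together. No measurement on hand accounts for the step.

Branching, chain length and the loss of the oxygens remain unseparated. A straight n-butyl chain and a 3-methoxypropyl chain at this nitrogen would be informative.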